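This account rests on a few compounds, and the source may have more. Where it says the series, first, only, none or still open, it means among the compounds named here.

Measured so far:
compound 1, `CCOC(=O)c1cnn2c1N(C(=O)Nc1cccc3ccccc13)C(c1ccccc1)C2` — 13.8 nM in a functional assay on cells (Neutrophil, Homo sapiens) for inhibition, with a stated time of 10 min; a higher number here means a weaker inhibitor, a lower number a stronger inhibitor
compound 2, `NC(=O)c1cnn2c1N(C(=O)Nc1ccccc1F)C(c1ccccc1)C2` — a limit of > 1000 nM in this assay
compound 3, `NC(=O)c1cnn2c1N(C(=O)Nc1ccc(F)cc1)C(c1ccccc1)C2` — 11.4 nM in this assay

Compound 3 gives the lowest of the two numbers in this assay; compound 1 sits nearest, within the scatter, so no order between the two can be claimed. For compound 2 the assay reports only a limit, (the limit of > 1000 nM in this assay, at which 1 of the 3 values shown sits). Going by the values given here, the one measured step, an at least 87-fold lower number from compound 2 to compound 3 (1.94 log units; beyond the scatter), shows that the aryl group on the amide-type nitrogen can swing the result widely.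

Compound 4, `NC(=O)c1cnn2c1N(C(=O)Nc1cccc3ccccc13)C(c1ccccc1)C2`, is not yet measured. It differs from compound 3 as follows: naphthalen-1-yl in place of 4-fluorophenyl on an amide-type nitrogen. Among the compounds with values here, no measured step replaces a fluorophenyl with naphthalen-1-yl, so the step from compound 2 to compound 3 bears on it only as a warning about the size such a change can take. Compound 1 carries the same naphthalen-1-yl group with an ester in place of the amide and gives 13.8 nM, close to the number for compound 3. On that basis compound 4 is expected to stay near compound 3, with a step of a 1.3-fold higher number from compound 3 to compound 4 (0.12 log units; within the scatter) estimated to lie within the scatter. The estimated value for compound 4 in this assay is 15 nM, between 5 nM and 60 nM.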

Compound 4, half-maximal inhibitory concentration: 110 nM
Beside the measured number, compound 4's estimate is 7.3-fold (0.87 log units) below it, outside the stated range (above it).
By their numbers in this assay, from the lowest: compounds 3 and 1 (each within the scatter of the next); then compound 4. At a limit, above all of these: compound 2.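

In this assay, naphthalen-1-yl in place of 4-fluorophenyl on the amide-type nitrogen gives a 9.6-fold higher number from compound 3 to compound 4 (0.98 log units; beyond the scatter), so this position separates two aryl groups that had not been compared on the same core. Amino in place of ethoxy on the carbonyl carbon gives an 8.0-fold higher number from compound 1 to compound 4 (0.90 log units; beyond the scatter), so the low number seen with naphthalen-1-yl in compound 1 does not carry over to the amide. Naphthalen-1-yl in place of 2-fluorophenyl gives an at least 9.0-fold lower number from compound 2 to compound 4 (0.95 log units; beyond the scatter), and the number for compound 2 is a limit: the limit of > 1000 nM in this assay, at which 1 of the 4 values shown sits.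

Open, on these data alone, is how unsubstituted phenyl, 4-chlorophenyl or 4-methoxyphenyl on the amide-type nitrogen would compare with 4-fluorophenyl. Also open, as far as these compounds go, is whether the ethyl ester keeps its standing with 4-fluorophenyl, and how a carboxylic acid would behave at the carbonyl carbon.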